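The source may hold more compounds than are shown below. What is called first, only, known or untested is meant among the compounds shown, and "the series" means these compounds.

Of the compounds shown here, three built on one shared core have been tested in a functional assay on the whole organism (strain Swiss albino) for inhibition, with Mus musculus as the target, in the formalin test, with stated times of 5 min and 30 min, at a dose of 100 mg/kg by the intraperitoneal route; a lower number here means less inhibition, a higher number more inhibition at the dose given (going by the name of the read-out). Compound 1 `Nn1c(CCc2ccc(O)cc2)nnc1SCC(=O)N1N=C(c2cccs2)CC1c1ccc(F)cc1` gives 73.7% in this assay, and compound 2 `Nn1c(CCc2ccc(O)cc2)nnc1SCC(=O)N1N=C(c2cccs2)CC1c1ccc(Cl)cc1` gives 68.7%. Compound 3 `Cc1ccc(C2CC(c3cccs3)=NN2C(=O)CSc2nnc(CCc3ccc(O)cc3)n2N)cc1` gives 35.4%, the lowest of the three numbers; its nearest neighbour in this assay is compound 2 and its furthest is compound 1, both beyond the scatter.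

Among the measured steps, a number 5 percentage points lower from compound 1 to compound 2 (within the scatter) is too small to mean anything, while a number 38.3 percentage points lower from compound 1 to compound 3 (beyond the scatter) and a number 33.3 percentage points lower from compound 2 to compound 3 (beyond the scatter) are both large and downward. Both of these large steps put methyl in place of a halogen on the same aromatic carbon, so exchanging that methyl again is the change that matters most here.

Compound 4 `CN(C)c1ccc(C2CC(c3cccs3)=NN2C(=O)CSc2nnc(CCc3ccc(O)cc3)n2N)cc1` is the next member, and it differs from compound 3 in one place: dimethylamino in place of methyl on an aromatic carbon. For the measured compounds named here, no measured step shows what a dimethylamino does on that aromatic carbon, so the direction is open. The methyl that gave compound 3 its low number is removed, which speaks for some recovery, yet a group unlike the halogens enters. Compound 4 is therefore estimated to land near 47%, most likely between 25% and 70%. This estimate means a step of a number 11.6 percentage points higher from compound 3 to compound 4 (beyond the scatter).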

Compound 4, a percentage reported as inhibition, in the whole organism at one dose (the size of the read-out at that dose, not a potency): 31.3%
Compound 4: the middle estimate sits 15.7 percentage points above what was measured; measured number inside the range.
By their numbers in this assay, from the lowest: compounds 4 and 3 (each within the scatter of the next); then compounds 2 and 1 (each within the scatter of the next).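

In this assay, dimethylamino in place of methyl on this aromatic carbon gives a number 4.1 percentage points lower from compound 3 to compound 4 (within the scatter), even though the entering group carries a nitrogen and a hydrogen-bond acceptor that methyl lacks. Compared with the halogens, the same group gives a number 37.4 percentage points lower from compound 2 to compound 4 (beyond the scatter) and a number 42.4 percentage points lower from compound 1 to compound 4 (beyond the scatter), so the large gap first seen with methyl also appears with a second, quite different non-halogen group. Across these four compounds, the values at this position therefore split into a fluoro and chloro pair and a methyl and dimethylamino pair, with no compound going against that split, but no measurement given here offers a reason for it.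

The compounds shown leave open whether bromo, a further halogen, would join the fluoro and chloro pair, and whether methoxy, trifluoromethyl or a plain hydrogen on this carbon would fall with either pair. They also leave open whether fluoro would hold its value on another carbon of the same ring, and whether the split would survive a change elsewhere on the shared core.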